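Swapping Isopropyl for Benzyl on a Charged Core

The source may hold more compounds than are shown below. What is called first, only, known or untested is meant among the compounds shown, and "the series" means these compounds.

Compound 1, `CO/N=c1\[nH]cnc2c1[n+](C/C=C(\C)CC/C=C(\C)CCC=C(C)C)cn2C`: 1240 nM
Compound 2, `CO/N=c1\[nH]cnc2c1[n+](C/C=C(\C)CC/C=C(\C)CC/C=C(\C)CCC=C(C)C)cn2C(C)C`: 886 nM

Both were tested in a functional assay on cells (Homo sapiens) for cytotoxicity; a higher number here means a weaker inhibitor, a lower number a stronger inhibitor. Compound 2 gives 886 nM, and compound 1 gives 1240 nM; the gap between them lies within the usual scatter of repeated measurements, so the two stand level, and compound 2 merely shows the lower of the two numbers.

Compound 3, `CO/N=c1\[nH]cnc2c1[n+](C/C=C(\C)CC/C=C(\C)CC/C=C(\C)CCC=C(C)C)cn2Cc1ccccc1`, has not yet been tested. It differs from compound 2 in one place: benzyl in place of isopropyl on an aromatic nitrogen. Going by the values given here, no pair of measured compounds differs in just this way, so the size of this step cannot be read from the data and has to be estimated. The step of a 1.2-fold lower number from compound 2 to compound 3 (0.07 log units; within the scatter) is expected to be small, probably not beyond the scatter, and its direction is uncertain. Compound 3 is therefore estimated at 750 nM, with a range from 250 nM to 2200 nM.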

Compound 3, half-maximal inhibitory concentration: 1040 nM
For compound 3 the middle estimate is 1.4-fold (0.14 log units) below the measured one; low and high end bracket the measured number.
By their numbers in this assay, from the lowest: compounds 2, 3 and 1 (each within the scatter of the next).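

In this assay benzyl in place of isopropyl on an aromatic nitrogen gives a 1.2-fold higher number from compound 2 to compound 3 (0.07 log units; within the scatter) and so leaves the two compounds level. Going by these compounds alone, this is the first comparison here that changes a single place, and it shows that at this nitrogen a group of 7 heavy atoms with one six-membered aromatic ring, taking the place of a group of 3 heavy atoms with no ring, does not move the number beyond the scatter. No measurement at hand offers a reason for this level result.

The compounds shown leave open what a group of another kind would do on this nitrogen, such as a chain ending in an amine or a carboxylic acid. As far as these compounds go, it also stays open what a fluorine or a methoxy group on the benzyl ring would do.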